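Compound 2 to compound 4: swapping the terminal amine

The compounds below may be only part of what the source reports. "The series", "measured", "known", "first", "only" and "open" are said of these compounds alone.

Measured in a functional assay on L02 cells (Homo sapiens) for inhibition; a lower number here means a stronger inhibitor, a higher number a weaker inhibitor:
- Compound 1 `O=C(CC(CC(=O)NC1Cc2ccccc2C1)c1ccc(Cl)cc1)NCCN1CCCCC1` gives 70400 nM
- Compound 2 `CCN(C(=O)CC(CC(=O)NCCN1CCCCC1)c1ccc(Cl)cc1)C1Cc2ccccc2C1` gives 84200 nM
- Compound 3 `CN(C(=O)CC(CC(=O)NCCN1CCCC1)c1ccc(Cl)cc1)C1Cc2ccccc2C1` gives 81500 nM

Compound 2 cannot be told apart from the other two compounds, as its value lies within the scatter of both compound 1 and compound 3. Compound 4 `CCN(CC)CCNC(=O)CC(CC(=O)N(CC)C1Cc2ccccc2C1)c1ccc(Cl)cc1` departs from compound 2 in one place: diethylamino in place of piperidin-1-yl on a saturated chain carbon, two bonds along the chain from an amide-type nitrogen. In short, diethylamino stands in place of piperidin-1-yl on a saturated chain carbon, two bonds along the chain from an amide-type nitrogen.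

Within the data shown here, no measured step tests this swap. Among the measured compounds shown here, the only step available is a 1.2-fold higher number from compound 1 to compound 2 (0.08 log units; within the scatter), which is a different change, ethyl in place of hydrogen on an amide-type nitrogen, and it stays within the scatter. With so little variation among the three values, no shift beyond the scatter is expected in this assay. An estimated step of a 1.1-fold lower number from compound 2 to compound 4 (0.02 log units; within the scatter) is expected. For compound 4 the expected value is 80000 nM, within an estimated range of 45000 nM to 140000 nM.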

Compound 4, half-maximal inhibitory concentration: 78400 nM
Compound 4: middle estimate off by 1.0-fold (0.01 log units), on the high side; the measured number falls inside the stated range.
By their numbers in this assay, from the lowest: compounds 1, 4, 3 and 2 (each within the scatter of the next).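

In this assay, the swap of piperidin-1-yl for diethylamino on a saturated chain carbon, two bonds along the chain from an amide-type nitrogen, gives a 1.1-fold lower number from compound 2 to compound 4 (0.03 log units; within the scatter). Among these compounds, this is the first direct reading of this terminal amine, and it shows that replacing the six-membered non-aromatic ring with an open diethylamino group makes no difference that can be told from the scatter. No measured information on these groups bears on the result, so it comes without an explanation.

The compounds shown leave open whether a morpholin-4-yl group or an unsubstituted amine at this place would move the number beyond the scatter. They also leave open whether a carboxylic acid or a longer chain in place of the 2-(diethylamino)ethyl group would do so.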